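Removing a Methoxy Group from an Ester-Linked Cinnamic Acid

The compounds below may be only part of what the source reports. "The series", "measured", "known", "first", "only" and "open" are said of these compounds alone.

Three measured compounds share one core. In a functional assay on EA.hy 926 cells (Homo sapiens) for cytotoxicity, read by MTT assay, with stated times of 24 h and 12 h, tested at 25 uM (on this read-out lower numbers stand for a weaker effect and higher numbers for a stronger effect at the one concentration tested), compound 1 `Cc1nc(C)c(C(=O)Oc2ccccc2/C=C/C(=O)O)nc1C` gives 61.8%. In this assay compound 2 `COc1ccc(/C=C/C(=O)O)c(OC(=O)c2nc(C)c(C)nc2C)c1` gives -52.1% and compound 3 `COc1ccc(/C=C/C(=O)O)cc1OC(=O)c1nc(C)c(C)nc1C` gives 128% which is the highest of the three numbers. Compound 2 and compound 1 differ in one place, hydrogen in place of methoxy on an aromatic carbon and the step is a number 113.9 percentage points higher from compound 2 to compound 1 (beyond the scatter). Compound 3 and compound 2 are built from the same atoms joined differently; the difference between the two cores is not broken down here. Compound 4 `Cc1nc(C)c(C(=O)Oc2cccc(/C=C/C(=O)O)c2)nc1C` is not yet measured and differs from compound 3 by hydrogen in place of methoxy on an aromatic carbon. Among the compounds with values here, this is the same kind of change as the one from compound 2 to compound 1 but not the same: in compound 3 the methoxy sits ortho to a large group, whereas in compound 2 it sits meta to a large group. Within the data shown here, the one earlier example of this change rose sharply. Among the measured compounds shown here, the step from compound 3 to compound 4 is expected to be smaller, a number 12 percentage points higher from compound 3 to compound 4 (beyond the scatter) since compound 3 already reads 128% and only one prior example exists. Compound 4 is estimated at 140% with a likely range from 105% to 175% in this assay.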

Compound 4, a percentage reported as activity, at one concentration (the size of the read-out at that concentration, not a potency): 64.3%
Compound 4: the middle estimate sits 75.7 percentage points above what was measured; measured number outside the range, below it.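

In this assay, replacing the methoxy group with hydrogen gives a number 63.7 percentage points lower from compound 3 to compound 4 (beyond the scatter), so the rise seen on the earlier core does not recur here. The same swap therefore moves the read-out in opposite directions on the two cores, and the gap between the two steps is larger than measurement scatter would explain: the same change on two cores in this assay, a number 113.9 percentage points higher (beyond the scatter) from compound 2 to compound 1 and a number 63.7 percentage points lower (beyond the scatter) from compound 3 to compound 4, 177.6 percentage points apart, beyond the scatter of two such steps. In this series, the result of removing this methoxy group on one core cannot be carried over to the other, but two pairs of compounds show neither why the steps differ nor any rule for further cores.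

Going by these compounds, it remains open how a hydroxyl group, an ethoxy group or a fluorine atom on the same aromatic carbon would read on each core. On these data alone, it is also open whether the two cores would still part ways with an amide in place of the ester link.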